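The compounds below may be only part of what the source reports. "The series", "measured", "known", "first", "only" and "open" are said of these compounds alone.

Measured in a functional assay on A549 cells (Homo sapiens) for cytotoxicity, read by MTT assay, with a stated time of 48 h; a higher number here means a weaker inhibitor, a lower number a stronger inhibitor:
- Compound 1 `CC1(C)CCC[C@]2(C)[C@@H](CC[C@@](C)(O)/C=C/c3ccccc3)[C@](C)(O)CC[C@@H]12`: 3150 nM
- Compound 2 `Cc1ccc(C)c(/C=C/[C@](C)(O)CC[C@@H]2[C@@]3(C)CCCC(C)(C)[C@@H]3CC[C@@]2(C)O)c1`: 3320 nM
- Compound 3 `CC(C)(C)c1ccc(/C=C/[C@](C)(O)CC[C@@H]2[C@@]3(C)CCCC(C)(C)[C@@H]3CC[C@@]2(C)O)cc1`: 45000 nM

Compound 3 has the highest number of the three, which makes it the weakest inhibitor of this small set. The next compound to consider is compound 4 `Cc1cccc(C)c1/C=C/[C@](C)(O)CC[C@@H]1[C@@]2(C)CCCC(C)(C)[C@@H]2CC[C@@]1(C)O`, which keeps the shared core and alters only the aromatic group: 2,6-dimethylphenyl in place of 4-(tert-butyl)phenyl on a double-bonded chain carbon bound to a double-bonded chain carbon. In short, 2,6-dimethylphenyl replaces 4-(tert-butyl)phenyl.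

For the measured compounds named here, three measured steps bear on this change. Placing tert-butyl on the aromatic ring of compound 1 gave a large step, a 14-fold higher number from compound 1 to compound 3 (1.15 log units; beyond the scatter). The swap from 2,5-dimethylphenyl to 4-(tert-butyl)phenyl was just as large, a 14-fold higher number from compound 2 to compound 3 (1.13 log units; beyond the scatter). Replacing phenyl with 2,5-dimethylphenyl, by contrast, gave a 1.1-fold higher number from compound 1 to compound 2 (0.02 log units; within the scatter), which lies within the scatter.

Going by the values given here, compound 4 loses the tert-butyl group and carries a dimethylphenyl group, as compound 2 does, although no measured compound has the 2,6-dimethylphenyl group itself. A large step to a lower number in this assay is therefore expected, landing near compound 2 at 3320 nM. The expected size of the step is an 11-fold lower number from compound 3 to compound 4 (1.05 log units; beyond the scatter). For compound 4 the estimated value is 4000 nM, with an expected range of 1500 nM to 12000 nM.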

Compound 4, half-maximal inhibitory concentration: 3340 nM
Compound 4: middle estimate off by 1.2-fold (0.08 log units), on the high side; measured number inside the range.
By their numbers in this assay, from the lowest: compounds 1, 2 and 4 (each within the scatter of the next); then compound 3.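

In this assay, putting 2,6-dimethylphenyl in place of 4-(tert-butyl)phenyl gives a 13-fold lower number from compound 3 to compound 4 (1.13 log units; beyond the scatter), so a ring without the tert-butyl group again reads like the other non-tert-butyl compounds. Rearranging the two methyl groups changes nothing that can be told apart, with a 1.0-fold higher number from compound 2 to compound 4 (0.00 log units; within the scatter), and neither does comparison with the plain phenyl ring, with a 1.1-fold higher number from compound 1 to compound 4 (0.03 log units; within the scatter); at this place on the double-bonded chain carbon, phenyl and both dimethylphenyl groups therefore form one level, and among these four compounds only compound 3 stands apart. Nothing measured here explains why compound 3 differs from the others.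

The compounds shown leave open whether the large step belongs to the tert-butyl group alone or would also appear with a smaller group in its place, such as 4-methylphenyl or 4-isopropylphenyl. On these data alone, how a ring carrying an amine or a carboxylic acid would read in this assay also remains open, as does whether a longer chain between the double bond and the ring would keep compound 4's level.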